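Trifluorophenyl Tail in Place of Phenoxy on Compound 3

The source may report more compounds than this note shows. Statements on the series, on what has been measured and on what is new or still open speak of the compounds shown alone.

Compound 1, `Cc1c(Cl)cccc1CCCCOc1ccc(C#Cc2cccc3c(CCCC(=O)O)c(C)n(CCC(=O)O)c23)cc1`, gives 17 nM in a functional assay on CHO-K1 cells for antagonist activity at cysteinyl leukotriene receptor 1 (Homo sapiens), read by fluorescence and calcium flux, with stated times of 30 min and 1 h; on this read-out lower numbers stand for stronger inhibition and higher numbers for weaker inhibition.
Compound 2, `Cc1c(Cl)cccc1CCCCOc1ccc(C#Cc2cccc3c(CCC(=O)O)c(C)n(CCCCC(=O)O)c23)cc1`, gives 25 nM in this assay.
Compound 3, `O=C(O)CCCc1cn(CC(=O)O)c2c(/C=C/c3ccc(OCCCCOc4ccccc4)cc3)cccc12`, gives 1.5 nM in this assay.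

Compound 3 stands lowest of the three numbers in this assay. Its nearest neighbour is compound 1, whose number is higher by a gap beyond the usual scatter, and compound 2 lies further still, also beyond the scatter. Compound 3 therefore stands apart as the strongest inhibitor of the three.

Compound 4, `O=C(O)CCCc1cn(CC(=O)O)c2c(/C=C/c3ccc(OCCCCc4c(F)ccc(F)c4F)cc3)cccc12`, is built from compound 3 by one change: 2,3,6-trifluorophenyl in place of phenoxy on a saturated chain carbon, four bonds along the chain from an oxygen on an aromatic ring. Among the compounds with values here, no pair of measured compounds shows this change, so there is nothing to read a step from directly. The carboxylic acid groups and the rest of the shared core are untouched, and only the far end of the chain changes. He expects the step in this assay from compound 3 to compound 4 to be small and in no clear direction, most likely within the scatter, with the estimated step being a 1.7-fold higher number from compound 3 to compound 4 (0.22 log units; within the scatter). For compound 4 he estimates 2.5 nM, in a range from 0.8 nM to 8 nM.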

Compound 4, half-maximal inhibitory concentration in the cysteinyl leukotriene receptor 1 assay: 1 nM
The estimate for compound 4 lay 2.5-fold (0.40 log units) above the measured number; measured number inside the range.
By their numbers in the cysteinyl leukotriene receptor 1 assay, from the lowest: compounds 4 and 3 (each within the scatter of the next); then compounds 1 and 2 (each within the scatter of the next).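

In the cysteinyl leukotriene receptor 1 assay the change gives a 1.5-fold lower number from compound 3 to compound 4 (0.18 log units; within the scatter) and so, at this position on a saturated chain carbon, 2,3,6-trifluorophenyl reads the same as phenoxy within the scatter, even though phenoxy with 1 hydrogen-bond acceptor leaves and 2,3,6-trifluorophenyl with 0 hydrogen-bond acceptors and 3 fluorine enters. In a physicochemical assay for permeability, using PAMPA, with a stated time of 4 h, at pH 6.2, tested at 50 uM (a lower number here means that the compound crosses the layer more slowly, a higher number that the compound crosses the layer faster), compound 3 gives 1.6 10^-6 cm/s and compound 4 gives 1.4 10^-6 cm/s and the same change gives a 1.1-fold lower number from compound 3 to compound 4 (0.06 log units; within the scatter) and thus also stays within the scatter, so this one pair separates the two groups on neither read-out. Nothing in the data at hand accounts for this result.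

Going by these compounds, whether an amine or a cyclohexyl group at the same chain end would read alike remains open, as does the effect of a longer chain. This single pair also cannot say whether 2,3,6-trifluorophenyl would behave the same way on another core.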